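The source may hold more compounds than are shown below. What is called first, only, known or untested is meant among the compounds shown, and "the series" means these compounds.

Compound 3, `O=C1/C(=C/c2ccc(Cl)cc2)C=C(c2ccc(Cl)cc2)N1Cc1ccccc1`, is the point of departure. In a functional assay on the whole organism (strain Wistar) for inhibition, with Rattus norvegicus as the target, with stated times of 30 min and 3 h, at a dose of 20 mg/kg by the oral route (on this read-out lower numbers stand for less inhibition and higher numbers for more inhibition at the one dose given (going by the name of the read-out)), compound 3 gives 88.9%. Two further compounds give the setting. Compound 1, `O=C1OC(c2ccc(Cl)cc2)=C/C1=C\c1ccccc1Cl`, in this assay gives 81.5%, and compound 2, `COc1cc(/C=C2\C=C(c3ccc(Cl)cc3)OC2=O)ccc1OC(C)=O`, in this assay gives 37%. Among the measured compounds shown here, of these three numbers the one for compound 3 stands at the top, yet its distance to compound 1 lies within the usual scatter of such measurements, so the two cannot be told apart; only compound 2 lies beyond the scatter, well below compound 3. For the measured compounds named here, no pair among the measured compounds differs in a single place, so no measured step is at hand.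

The next compound, compound 4, is `O=C1/C(=C/c2ccc(F)cc2)C=C(c2ccc(Cl)cc2)N1Cc1ccccc1`. The change from compound 3 is fluoro in place of chloro on an aromatic carbon. Without a measured step of this kind to lean on, the step from compound 3 to compound 4 is expected to be small, in no direction beyond the scatter, and is estimated at a number 8.9 percentage points lower from compound 3 to compound 4 (within the scatter). Compound 4 is therefore expected to give about 80% in this assay, within a range from 60% to 95%.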

Compound 4, a percentage reported as inhibition, in the whole organism at one dose (the size of the read-out at that dose, not a potency): 89.5%
Compound 4: middle estimate off by 9.5 percentage points, on the low side; the measured number falls inside the stated range.
By their numbers in this assay, from the lowest: compound 2; then compounds 1, 3 and 4 (each within the scatter of the next).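

In this assay, among the compounds shown here, the change from 4-chlorophenyl to 4-fluorophenyl supplies the only measured step in one place, a number 0.6 percentage points higher from compound 3 to compound 4 (within the scatter). At this aromatic carbon, para to a large group, chloro and fluoro therefore cannot be told apart at the one dose given, so this exchange leaves the read-out without a discernible change. No supporting evidence explains this result.

What the compounds shown leave open is how an amine, a carboxylic acid or a trifluoromethyl group at this same place would read, since two halogens say little about groups of other kinds. As far as these compounds go, it also remains open whether the same exchange on the other 4-chlorophenyl group of the shared core would read alike, and whether compound 3 and compound 4 would stay indistinguishable at other doses.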